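Shifting Three Fluorines Around a Benzyl Ring

The source may report more compounds than this note shows. Statements on the series, on what has been measured and on what is new or still open speak of the compounds shown alone.

Three compounds share one core and differ only in the aryl group on a saturated chain carbon bound to an amine nitrogen in a ring. In an assay on FRT cells for positive allosteric modulation of Cystic fibrosis transmembrane conductance regulator variant N1303K (Homo sapiens), in the presence of a further agent that is not named here (a lower number here means that less compound is needed, a higher number that more compound is needed for the effect), compound 1 `COc1ccc2[nH]c3c(c2c1)CCNC31CCN(Cc2ccc([N+](=O)[O-])cc2F)CC1` gives 5900 nM. Compound 2 `COc1ccc2[nH]c3c(c2c1)CCNC31CCN(Cc2c(F)ccc(Cl)c2F)CC1` gives 1500 nM in this assay, and compound 3 `COc1ccc2[nH]c3c(c2c1)CCNC31CCN(Cc2cc(F)c(F)c(F)c2)CC1` gives 2600 nM. The other two steps are a 2.3-fold lower number from compound 1 to compound 3 (0.36 log units; beyond the scatter) and a 1.7-fold higher number from compound 2 to compound 3 (0.24 log units; within the scatter); the largest step, a 3.9-fold lower number from compound 1 to compound 2 (0.59 log units; beyond the scatter), came from exchanging the 2-fluoro-4-nitrophenyl for the 3-chloro-2,6-difluorophenyl. Compound 4 `COc1ccc2[nH]c3c(c2c1)CCNC31CCN(Cc2ccc(F)c(F)c2F)CC1` carries 2,3,4-trifluorophenyl in place of 3,4,5-trifluorophenyl on a saturated chain carbon bound to an amine nitrogen in a ring, so the three fluorines stay and only their placing on the ring changes. Among the measured compounds shown here, no measured step tests such a rearrangement directly; the steps between fluorine-bearing rings, a 1.7-fold higher number from compound 2 to compound 3 (0.24 log units; within the scatter) and a 3.9-fold lower number from compound 1 to compound 2 (0.59 log units; beyond the scatter), suggest these rings land fairly close together. The step for compound 4 is therefore expected to be small, a 1.3-fold lower number from compound 3 to compound 4 (0.11 log units; within the scatter). Compound 4 is estimated at 2000 nM, within a range from 800 nM to 5000 nM.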

Compound 4, half-maximal effective concentration: 4100 nM
Beside the measured number, compound 4's estimate is 2.1-fold (0.31 log units) below it; the measured number falls inside the stated range.
By their numbers in this assay, from the lowest: compounds 2, 3, 4 and 1 (each within the scatter of the next, the first and the last beyond it).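

Moving the three fluorines from the 3,4,5-trifluorophenyl to the 2,3,4-trifluorophenyl pattern, with the same atoms joined differently, gives a 1.6-fold higher number from compound 3 to compound 4 (0.20 log units; within the scatter), so in this assay this rearrangement on the saturated chain carbon bound to an amine nitrogen in a ring cannot be told apart from ordinary repeat variation. The new ring does, however, separate from the 3-chloro-2,6-difluorophenyl group, with a 2.7-fold higher number from compound 2 to compound 4 (0.44 log units; beyond the scatter), while it stays unresolved from the 2-fluoro-4-nitrophenyl group, with a 1.4-fold lower number from compound 1 to compound 4 (0.16 log units; within the scatter). Nothing available here bears on what lies behind these numbers.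

From the compounds shown here alone, how the number would respond to an amine or a carboxylic acid on this ring stays open. So does the effect of a longer chain in place of the single saturated carbon.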